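The source may report more compounds than this note shows. Statements on the series, on what has been measured and on what is new or still open speak of the compounds shown alone.

Compound 1 `COc1ccc(C2=NN(C3=NC(=O)/C(=C4\C(=O)Nc5ccc(Br)cc54)S3)C(c3ccc(Cl)cc3)C2)cc1` carries a bromo group on the shared core. In a functional assay on cells (Cancer cell lines, Homo sapiens) for cytotoxicity, read by sulforhodamine B assay, with a stated time of 48 h (on this read-out higher numbers stand for weaker inhibition of growth and lower numbers for stronger inhibition of growth), compound 1 gives 1010 nM. Compound 2 `COc1ccc(C2=NN(C3=NC(=O)/C(=C4\C(=O)Nc5ccc(Cl)cc54)S3)C(c3ccc(Cl)cc3)C2)cc1` is its chloro counterpart, and in this assay compound 2 gives 740 nM. The change between them is chloro in place of bromo on an aromatic carbon, and the step it made is a 1.4-fold lower number from compound 1 to compound 2 (0.14 log units; within the scatter).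

Compound 3 `CN(C)c1ccc(C2CC(c3ccccc3)=NN2C2=NC(=O)/C(=C3\C(=O)Nc4ccc(Br)cc43)S2)cc1` belongs to a second core; how this core differs from that of compound 1 is not broken down here. In this assay compound 3 gives 720 nM, a number close to those of compound 1 and compound 2.

Compound 4 `CN(C)c1ccc(C2CC(c3ccccc3)=NN2C2=NC(=O)/C(=C3\C(=O)Nc4ccc(Cl)cc43)S2)cc1` has not yet been measured in this assay. Among the compounds with values here, it differs from compound 3 by chloro in place of bromo on an aromatic carbon, which is the same change as the one from compound 1 to compound 2, at the same place. Since the earlier step was a 1.4-fold lower number from compound 1 to compound 2 (0.14 log units; within the scatter), the step for compound 4 is expected to be of similar size, namely a 1.3-fold lower number from compound 3 to compound 4 (0.12 log units; within the scatter). Compound 4 is therefore estimated at 550 nM in this assay, with a likely range from 300 nM to 1100 nM.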

Compound 4, concentration for total growth inhibition: 690 nM
For compound 4 the middle estimate is 1.3-fold (0.10 log units) below the measured one, within the range that was stated.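

On the second core, chloro in place of bromo on an aromatic carbon gives a 1.0-fold lower number from compound 3 to compound 4 (0.02 log units; within the scatter) in this assay. Neither this step nor the earlier one lies beyond the scatter, so the swap has no readable effect on either core, and these two pairs do not show how it would carry over to a core where it moved the number measurably. Within these two pairs, the two cores answer to the change alike: the same change on two cores in this assay, a 1.4-fold lower number (0.14 log units; within the scatter) from compound 1 to compound 2 and a 1.0-fold lower number (0.02 log units; within the scatter) from compound 3 to compound 4, 1.3-fold (0.12 log units) apart, within the scatter of two such steps

The compounds shown carry only bromo or chloro at this place, which leaves open how a fluoro group, a methoxy group, a nitro group or an amine there would read, and whether any of them would give a step beyond the scatter. Also open, from the compounds shown here alone, is whether the same swap would stay this small with a carboxylic acid or a longer chain on the aromatic rings at the other end of these molecules.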